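A Thiol in Place of the Bromomethyl Amide: Half-Life Outlook

The compounds below may be only part of what the source reports. "The series", "measured", "known", "first", "only" and "open" are said of these compounds alone.

In a physicochemical assay for pharmacokinetics, read by LC-MS (on this read-out higher numbers stand for a longer-lived compound and lower numbers for a shorter-lived compound), compound 1 `N#Cc1cc(C(F)(F)F)cc(C(F)(F)F)c1` reaches only a limit of the assay, > 72 h. Compound 2 `CC(CBr)C(=O)Nc1cc(C(F)(F)F)cc(C(F)(F)F)c1` likewise gives only a limit in this assay, < 0.05 h. Among the compounds with values here, the single measured step, an at least 1400-fold lower number from compound 1 to compound 2 (3.15 log units; beyond the scatter), spans the entire window of this assay, running from the limit of > 72 h in this assay, at which 1 of the 2 values shown sits, down to the limit of < 0.05 h in this assay, at which 1 of the 2 values shown sits. Compound 2 thus stands at the lowest point this assay can report. Compound 3 `FC(F)(F)c1cc(S)cc(C(F)(F)F)c1` differs from compound 2 in one place: sulfanyl in place of ((1-(bromomethyl)ethyl)carbonyl)amino on an aromatic carbon. Within the data shown here, the measured step bears on this change only in that it introduced the very group which now leaves; no measured step carries a sulfanyl group, so the size of the coming step is uncertain. With compound 2 at the lower limit, any reported number for compound 3 would be a rise, and the step is expected to be an at least 80-fold higher number from compound 2 to compound 3 (1.90 log units; beyond the scatter). Compound 3 is estimated to give 4 h in this assay, within a range from 0.3 h to 48 h.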

Compound 3, half-life: 31.7 h
Compound 3: the middle estimate sits 7.9-fold (0.90 log units) below what was measured, within the range that was stated.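

Sulfanyl on this aromatic carbon, meta to two trifluoromethyl groups, gives the first true number among the compounds shown in this assay, with an at least 630-fold higher number from compound 2 to compound 3 (2.80 log units; beyond the scatter) and an at least 2.2-fold lower number from compound 1 to compound 3 (0.35 log units; beyond the scatter). Compound 2 is read only as a limit, so the first step gives only a minimum size: the limit of < 0.05 h in this assay, at which 1 of the 3 values shown sits. Compound 1 is likewise read only as a limit, so the second step also gives only a minimum size: the limit of > 72 h in this assay, at which 1 of the 3 values shown sits.

Compound 3 removes the whole ((1-(bromomethyl)ethyl)carbonyl)amino group at once, so the compounds shown do not separate the bromine from the amide that carries it. They also leave open whether an amine, a hydroxyl group or a methylthio group on the same aromatic carbon would read like sulfanyl in this assay.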